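Extending the chain from compound 3 to compound 4

A few compounds are considered here, and "the series" means these few. Any claim that something is new, unique, unknown or untested is made for them only; others in the source may bear on it.

Compound 3 `CCCCCCCCCCCC(=O)OCC(C)(C)CC1=C(O)C(=O)c2ccccc2C1=O` gives 249000 nM in an ADME assay on Vero cells (Chlorocebus sabaeus) for cytotoxicity, read by MTT assay; on this read-out lower numbers stand for stronger inhibition and higher numbers for weaker inhibition. Compound 1 `CCCCCCCCC(=O)OCC(C)(C)CC1=C(O)C(=O)c2ccccc2C1=O` gives 150000 nM, and the two lie close: a 1.7-fold higher number from compound 1 to compound 3 (0.22 log units; within the scatter). Compound 2 `CCCCCCCCCCC(=O)OCC(C)(C)CC1=C(O)C(=O)c2ccccc2C1=O` is reported only as a limit, > 233000 nM. That limit means an at least 1.5-fold higher number from compound 1 to compound 2 (0.19 log units; that floor lies within the scatter) offers only a floor, while a step that the limit leaves unreadable from compound 2 to compound 3 tells nothing. Compound 4 `CCCCCCCCCCCCCCCCCC(=O)OCC(C)(C)CC1=C(O)C(=O)c2ccccc2C1=O` differs from compound 3 by hexyl in place of hydrogen on a saturated chain carbon, ten or more bonds along the chain from a carbonyl carbon. This is a longer addition than any measured so far, yet the chain changes seen in this series, ethyl and propyl included, stayed within the scatter. The step expected is a 1.1-fold lower number from compound 3 to compound 4 (0.05 log units; within the scatter), with no change beyond the scatter. For compound 4 the estimate is 220000 nM, with an expected range from 100000 nM to 450000 nM.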

Compound 4, half-maximal inhibitory concentration: 15500 nM
The estimate for compound 4 lay 14-fold (1.15 log units) above the measured number; measured number below the stated range.
By their numbers in this assay, from the lowest: compound 4; then compounds 1 and 3 (each within the scatter of the next).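

Hexyl in place of hydrogen, on a saturated chain carbon, is the first change here to move the number in this assay clearly beyond the scatter: a 16-fold lower number from compound 3 to compound 4 (1.21 log units; beyond the scatter). Compound 4 also stands apart from the shorter esters, with a 9.7-fold lower number from compound 1 to compound 4 (0.99 log units; beyond the scatter) and an at least 15-fold lower number from compound 2 to compound 4 (1.17 log units; beyond the scatter), though the second step rests on a limit: the limit of > 233000 nM in this assay, at which 1 of the 4 values shown sits. Chain length in this series therefore has an effect that the shorter chains did not reveal.

On these data alone, whether the drop comes gradually or abruptly at chain lengths between those of compound 3 and compound 4 remains open. Also open, as far as these compounds go, is whether a longer chain, or an amine at the chain end, would keep the lower number.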